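The compounds below may be only part of what the source reports. "The series", "measured", "known", "first", "only" and "open" are said of these compounds alone.

Measured in a functional assay on U-937 cells (Homo sapiens); a lower number here means a stronger inhibitor, a higher number a weaker inhibitor:
- Compound 1 `COc1cc(C(=O)NS(=O)(=O)c2ccccc2C)ccc1Cc1cn(C(F)F)c2ccc(NC(=O)OC3CCCC3)cc12`: 0.4 nM
- Compound 2 `COc1cc(C(=O)NS(=O)(=O)c2ccccc2C)ccc1Cc1cn(C=O)c2ccc(NC(=O)OC3CCCC3)cc12`: 0.6 nM
- Compound 3 `COc1cc(C(=O)NS(=O)(=O)c2ccccc2C)ccc1Cc1cn(C(=O)N(C)C)c2ccc(NC(=O)OC3CCCC3)cc12`: 1 nM

Compound 1 stands at the low end of these numbers. The nearest measured step is a 1.5-fold higher number from compound 1 to compound 2 (0.18 log units; within the scatter), and the furthest is a 2.5-fold higher number from compound 1 to compound 3 (0.40 log units; beyond the scatter).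

Compound 4 `COc1cc(C(=O)NS(=O)(=O)c2ccccc2C)ccc1Cc1cn(C(=O)NCCN(C)C)c2ccc(NC(=O)OC3CCCC3)cc12` carries (2-(dimethylamino)ethyl)carbamoyl in place of difluoromethyl on an aromatic nitrogen.

The dimethylcarbamoyl step bears most directly on this change, while a 1.7-fold higher number from compound 2 to compound 3 (0.22 log units; within the scatter) also stays small. Among the measured compounds shown here, no measured compound carries the (2-(dimethylamino)ethyl)carbamoyl group, so the range stays wide. A modest move to a higher number is expected in this assay. The expected step is a 3.8-fold higher number from compound 1 to compound 4 (0.57 log units; beyond the scatter). For compound 4 the estimate is 1.5 nM, with an expected range of 0.5 nM to 5 nM.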

Compound 4, half-maximal inhibitory concentration: 0.1 nM
Estimate against measurement, compound 4: 15-fold (1.18 log units) above, and the stated range ends above it.
By their numbers in this assay, from the lowest: compound 4; then compounds 1, 2 and 3 (each within the scatter of the next, the first and the last beyond it).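

On the aromatic nitrogen, (2-(dimethylamino)ethyl)carbamoyl gives a 4.0-fold lower number from compound 1 to compound 4 (0.60 log units; beyond the scatter) in this assay and so moves below difluoromethyl, showing that this position accepts the longer chain without loss. On the same carbonyl, the (2-(dimethylamino)ethyl)amino group gives a 10-fold lower number from compound 3 to compound 4 (1.00 log units; beyond the scatter) when it replaces dimethylamino and a 6.0-fold lower number from compound 2 to compound 4 (0.78 log units; beyond the scatter) when it replaces hydrogen, so the carbonyl alone does not account for the lower number. Nothing given here explains this gain.
Still open, going by these compounds, is whether the terminal dimethylamino group is required, as a chain ending in hydroxyl or methoxy would show. A longer propyl linker or a morpholine terminus also remains untested among the compounds shown.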